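Lengthening an Ether Chain from Ethoxy to Pentyloxy

A few compounds are considered here, and "the series" means these few. Any claim that something is new, unique, unknown or untested is made for them only; others in the source may bear on it.

Compound 1, `CCOc1ccc2oc(/C=C/[S+](C)[O-])cc(=O)c2c1`, in a functional assay on A549 cells (Homo sapiens) for cytotoxicity, with a stated time of 48 h; a higher number here means a weaker inhibitor, a lower number a stronger inhibitor: 1500 nM
Compound 2, `CCC(=O)Oc1ccc2oc(/C=C/[S+](C)[O-])cc(=O)c2c1`, in this assay: 2400 nM
Compound 3, `CC(C)COc1ccc2oc(/C=C/[S+](C)[O-])cc(=O)c2c1`, in this assay: 1100 nM

All three compounds share one core and differ only in the group carried on an oxygen on an aromatic ring. Compound 1 stands second highest of the three numbers. Its nearest neighbour is compound 3: a 1.4-fold lower number from compound 1 to compound 3 (0.13 log units; within the scatter). Its furthest is compound 2: a 1.6-fold higher number from compound 1 to compound 2 (0.20 log units; within the scatter). Between the other two, a 2.2-fold lower number from compound 2 to compound 3 (0.34 log units; beyond the scatter), the only step here that goes beyond the scatter.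

The unmeasured compound 4, `CCCCCOc1ccc2oc(/C=C/[S+](C)[O-])cc(=O)c2c1`, differs from compound 1 in one place: propyl in place of hydrogen on a saturated chain carbon, two bonds along the chain from an oxygen on an aromatic ring. Going by the values given here, the step that bears on this is the one from compound 1 to compound 3, where a larger saturated group also replaced a smaller one on the same oxygen, and that step stayed within the scatter. Among the compounds with values here, the one step beyond the scatter involved a propanoyl group, which compound 4 does not carry, so it gives little guidance.

For compound 4 the expectation in this assay is therefore a number close to that of compound 1, a 1.5-fold lower number from compound 1 to compound 4 (0.18 log units; within the scatter), with no change beyond the scatter. The estimate for compound 4 is 1000 nM, in a range from 400 nM to 2500 nM.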

Compound 4, half-maximal inhibitory concentration: 1600 nM
Compound 4: the middle estimate sits 1.6-fold (0.20 log units) below what was measured; measured number inside the range.
By their numbers in this assay, from the lowest: compounds 3, 1, 4 and 2 (each within the scatter of the next, the first and the last beyond it).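

Replacing hydrogen with propyl on a saturated chain carbon, two bonds along the chain from an oxygen on an aromatic ring, turns ethoxy into pentyloxy and leaves the reading in this assay within the scatter (a 1.1-fold higher number from compound 1 to compound 4 (0.03 log units; within the scatter)), so at this position a straight chain of this length gives no measurable change from the shorter ethyl group. The straight pentyl group also cannot be told apart from the branched isobutyl group (a 1.5-fold higher number from compound 3 to compound 4 (0.16 log units; within the scatter)) or from the propanoyl group (a 1.5-fold lower number from compound 2 to compound 4 (0.18 log units; within the scatter)), even though isobutyl and propanoyl differ from each other beyond the scatter, which leaves that single modest step as the only separation in the set. Nothing available here accounts for this flat picture.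

As far as these compounds go, it remains open whether a longer chain such as octyl, or a chain ending in an amine or a carboxylic acid, would keep the reading equally flat. Also open, from the compounds shown here alone, is whether a ring such as phenyl carried on the same oxygen would move the number beyond the scatter.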